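Butylamino in place of propoxy: what size of step?

The source may hold more compounds than are shown below. What is called first, only, known or untested is meant among the compounds shown, and "the series" means these compounds.

In a functional assay on WiDr cells (Homo sapiens) for inhibition, read by sulforhodamine B assay, with a stated time of 48 h (on this read-out higher numbers stand for weaker inhibition of growth and lower numbers for stronger inhibition of growth), compound 1 `Cc1cc(=O)oc2cc(N=C=[Se])ccc12` gives 4800 nM. Compound 2 `COC(=[Se])Nc1ccc2c(C)cc(=O)oc2c1` reaches only a limit of the assay, > 100000 nM. Compound 3 `CCCOC(=[Se])Nc1ccc2c(C)cc(=O)oc2c1` gives 42000 nM, the higher of the two exact numbers.

Compound 4 `CCCCNC(=[Se])Nc1ccc2c(C)cc(=O)oc2c1` differs from it in one place: butylamino in place of propoxy on a saturated chain carbon bound to a nitrogen on an aromatic ring. Among the measured compounds shown here, no measured step makes this exact swap. The closest guide, with ethyl in place of hydrogen, is an at least 2.3-fold lower number from compound 2 to compound 3 (0.37 log units; beyond the scatter). A larger rebuilding of the same group gave an at least 20-fold higher number from compound 1 to compound 2 (1.31 log units; beyond the scatter). As far as these compounds go, both steps rest on a limit, so their true sizes remain open.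

A modest move toward stronger inhibition of growth is therefore expected, a 2.3-fold lower number from compound 3 to compound 4 (0.37 log units; beyond the scatter). Compound 4 is estimated at 18000 nM, with an expected range from 5000 nM to 70000 nM.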

Compound 4, concentration for 50% growth inhibition: 3800 nM
For compound 4 the middle estimate is 4.7-fold (0.68 log units) above the measured one; the measured number lies below the stated range.
By their numbers in this assay, from the lowest: compounds 4 and 1 (each within the scatter of the next); then compound 3. At a limit, above all of these: compound 2.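

Butylamino in place of propoxy gives an 11-fold lower number from compound 3 to compound 4 (1.04 log units; beyond the scatter), so this place responds far more strongly than the earlier chain lengthening alone revealed, though the linking atom and the chain change together here. Butylamino in place of methoxy gives an at least 26-fold lower number from compound 2 to compound 4 (1.42 log units; beyond the scatter). As far as these compounds go, compound 2 stands at a limit of the assay, > 100000 nM, so the true size of that step stays open.

The compounds shown cannot separate the nitrogen from the longer chain: butoxy or propylamino would do so. From the compounds shown here alone, how a cyclic amine such as piperidine would read also remains open.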